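A few compounds are considered here, and "the series" means these few. Any claim that something is new, unique, unknown or untested is made for them only; others in the source may bear on it.

Compound 2 `NC(=O)c1c(NC(=O)c2ccccc2I)sc2c1CCN(C(=S)Nc1ccccc1Cl)C2` is the starting point of this step. In a functional assay on HeLa cells (Homo sapiens) for antiproliferative activity, with a stated time of 24 h (a higher number here means a weaker inhibitor, a lower number a stronger inhibitor), compound 2 gives > 50000 nM, which is a limit of the assay and not a number. Its two measured relatives are compound 1 `NC(=O)c1c(NC(=O)c2ccccc2Br)sc2c1CCN(C(=S)Nc1ccccc1Cl)C2` and compound 3 `COc1ccccc1C(=O)Nc1sc2c(c1C(N)=O)CCN(C(=S)Nc1ccccc1Cl)C2`. In this assay compound 1 gives 46900 nM. In this assay compound 3 gives > 50000 nM, again a limit and not a number. The step of an at least 1.0-fold higher number from compound 1 to compound 2 (0.02 log units; that floor lies within the scatter) and the step of an at least 1.0-fold higher number from compound 1 to compound 3 (0.02 log units; that floor lies within the scatter) are floors that stay within the scatter, and the step that the two limits leave unreadable from compound 2 to compound 3 cannot be read because of the limit of > 50000 nM in this assay, at which 2 of the 3 values shown sit. Compound 4 `NC(=O)c1c(NC(=O)c2ccccc2I)sc2c1CCN(C(=S)Nc1ccccc1Br)C2` has not yet been measured. It differs from compound 2 by bromo in place of chloro on an aromatic carbon. For the measured compounds named here, none of the measured steps changes this part of the molecule; all three exchange a group elsewhere, and none moved the number beyond the scatter. On that basis no step beyond the scatter is expected for compound 4 in this assay. Compound 4 is therefore estimated at 60000 nM, within a range from 30000 nM to 150000 nM. The expected step that the limit leaves unreadable from compound 2 to compound 4 would most likely leave compound 4 at a limit of the assay as well.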

Compound 4, half-maximal inhibitory concentration: > 50000 nM
Compound 4: no number, only a limit; the forecaster's own chance of this, stated with the estimate: 80%; the middle value is on the limit's open side.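

The step between compound 2 and compound 4 cannot be read in this assay, because both compounds give only a limit and not a number: the limit of > 50000 nM in this assay, at which 3 of the 4 values shown sit.

The compounds shown leave open whether bromo in place of chloro on this aromatic carbon changes the number in this assay at all.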